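The source may hold more compounds than are shown below. What is called first, only, known or untested is meant among the compounds shown, and "the series" means these compounds.

Compound 1 `c1ccc2c(-c3cn4ccnc4c(-c4ccc5ncn(C6CCCCC6)c5c4)n3)cccc2c1` gives 4.46%; compound 2 `c1ccc(Cn2cnc3ccc(-c4nc(-c5cccc6ccccc56)cn5ccnc45)cc32)cc1` gives 8.2%; compound 3 `c1cn2cc(-c3ccc4c(c3)ncn4C3CCCCC3)nc(-c3ccc4ncn(C5CCCCC5)c4c3)c2n1` gives 35.6%, all in a functional assay on HCT-15 cells (Homo sapiens) for inhibition, read by sulforhodamine B assay, with a stated time of 48 h, tested at 10 uM; on this read-out higher numbers stand for more inhibition at the one concentration tested (going by the name of the read-out) and lower numbers for less inhibition.

Compounds 1 and 2 share one core and differ by a single change, (benzyl in place of cyclohexyl on an aromatic nitrogen), which moved the read-out by a number 3.7 percentage points higher from compound 1 to compound 2 (within the scatter). Compound 3 carries a different core; the difference between the two cores is not broken down here. Compound 3 stands highest of the three measured numbers, and its steps to compound 1 and compound 2 are both beyond the scatter.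

Compound 4 `c1ccc(Cn2cnc3ccc(-c4nc(-c5ccc6c(c5)ncn6C5CCCCC5)cn5ccnc45)cc32)cc1` is not yet measured. It differs from compound 3 by benzyl in place of cyclohexyl on an aromatic nitrogen, the same change that was made from compound 1 to compound 2, at the same kind of place in both cases. Because that earlier change gave a number 3.7 percentage points higher from compound 1 to compound 2 (within the scatter), compound 4 is expected to stay close to compound 3, with a step of about a number 2.4 percentage points higher from compound 3 to compound 4 (within the scatter). On this footing compound 4 is estimated at 38% in this assay, with a likely range from 20% to 55%.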

Compound 4, a percentage reported as inhibition, at one concentration (the size of the read-out at that concentration, not a potency): -9.03%
For compound 4 the middle estimate is 47 percentage points above the measured one; measured number outside the range, below it.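

In this assay, the same swap of benzyl for cyclohexyl on an aromatic nitrogen gave a number 44.6 percentage points lower from compound 3 to compound 4 (beyond the scatter), so the near-silent result on the core of compound 1 did not carry over to the core of compound 3: the same change on two cores in this assay, a number 3.7 percentage points higher (within the scatter) from compound 1 to compound 2 and a number 44.6 percentage points lower (beyond the scatter) from compound 3 to compound 4, 48.4 percentage points apart, beyond the scatter of two such steps

Within these four compounds, then, the outcome of this change depends on the core that carries it, and a small step on one core is a poor guide to the step on another. The result rests on just two pairs, however, and does not show why the cores part ways, nor how the change would behave on any third core.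

The compounds shown leave open how a methyl group, or a longer chain ending in an amine, would read on that aromatic nitrogen of the core of compound 3. Also open, going by these compounds, is whether the contrast between the two cores would hold at other concentrations or in other cell lines.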